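The compounds below may be only part of what the source reports. "The series", "measured", "known", "first", "only" and "open" are said of these compounds alone.

Measured so far in a functional assay on A549 cells (Homo sapiens) for cytotoxicity, read by MTT assay, with a stated time of 48 h; on this read-out higher numbers stand for weaker inhibition and lower numbers for stronger inhibition:

Compound 1, `COc1ccc(-c2nc(C(=O)/C=C\Nc3ccc4[nH]ccc4c3)c3ccccn23)cc1`, gives 4800 nM.
Compound 2, `O=C(/C=C\Nc1ccc2cc[nH]c2c1)c1nc(-c2ccc(C(F)(F)F)cc2)n2ccccc12`, gives only a limit, > 30000 nM.
Compound 3, `O=C(/C=C\Nc1ccc2[nH]ccc2c1)c1nc(-c2ccc(C(F)(F)F)cc2)n2ccccc12`, gives 5190 nM.

Compound 3 holds the highest of the two numbers given, but compound 1 sits within the scatter of it: a 1.1-fold higher number from compound 1 to compound 3 (0.03 log units; within the scatter). Compound 2 is a limit of this assay (the limit of > 30000 nM in this assay, at which 1 of the 3 values shown sits). The step of an at least 5.7-fold lower number from compound 2 to compound 3 (0.76 log units; beyond the scatter) is beyond the scatter, so the ring on the amine nitrogen matters here.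

Compound 4, `COc1ccc(N/C=C\C(=O)c2nc(-c3ccc(C(F)(F)F)cc3)n3ccccc23)cc1`, differs from compound 3 by 4-methoxyphenyl in place of 1H-indol-5-yl on an amine nitrogen. Going by the values given here, no measured step covers this change directly. The step of a 1.1-fold higher number from compound 1 to compound 3 (0.03 log units; within the scatter) concerns a different place and does not bear on it. The step of an at least 5.7-fold lower number from compound 2 to compound 3 (0.76 log units; beyond the scatter) shows that changes on the amine nitrogen can move the number well beyond the scatter, in either direction. The expectation for compound 4 is therefore a somewhat higher number with a wide range: an estimated 9000 nM, between 2500 nM and 30000 nM. This estimate means an expected step of a 1.7-fold higher number from compound 3 to compound 4 (0.24 log units; within the scatter).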

Compound 4, half-maximal inhibitory concentration: 21800 nM
Compound 4: middle estimate off by 2.4-fold (0.38 log units), on the low side; the range from low to high includes it.
By their numbers in this assay, from the lowest: compounds 1 and 3 (each within the scatter of the next); then compound 4. At a limit, above all of these: compound 2.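

Replacing 1H-indol-5-yl with 4-methoxyphenyl on the amine nitrogen gives a 4.2-fold higher number from compound 3 to compound 4 (0.62 log units; beyond the scatter), so this position responds to a change of the whole group, not only to the attachment point of the indole seen between compound 2 and compound 3. Against the other indole the reading is weaker, with an at least 1.3-fold lower number from compound 2 to compound 4 (0.13 log units; that floor lies within the scatter), so compound 4 cannot be placed firmly against compound 2. Compound 2 remains a limit of the assay: the limit of > 30000 nM in this assay, at which 1 of the 4 values shown sits.

The compounds shown leave open whether an unsubstituted phenyl, a 4-aminophenyl or a 1H-indazol-5-yl on the amine nitrogen would stay near compound 3 or compound 4. Also open, as far as these compounds go, is whether the exchange of methoxy and trifluoromethyl, which gives a 1.1-fold higher number from compound 1 to compound 3 (0.03 log units; within the scatter) with 1H-indol-5-yl in place, behaves the same with 4-methoxyphenyl on the amine nitrogen.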